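A few compounds are considered here, and "the series" means these few. Any claim that something is new, unique, unknown or untested is made for them only; others in the source may bear on it.

Compound 1 `CC(O)(COc1cccc(C(F)(F)F)c1)C(=O)Nc1ccc(S(F)(F)(F)(F)F)cc1` and compound 2 `CC(O)(COc1cc(C(F)(F)F)cc(C(F)(F)F)c1)C(=O)Nc1ccc(S(F)(F)(F)(F)F)cc1` are built on the same core and differ at a single point: trifluoromethyl in place of hydrogen on an aromatic carbon. In a functional assay on LNCaP cells (Homo sapiens) for antiproliferative activity, read by propidium iodide staining, with a stated time of 96 h (a higher number here means a weaker inhibitor, a lower number a stronger inhibitor), compound 1 gives 24700 nM, while compound 2 gives 2300 nM. That change produced an 11-fold lower number from compound 1 to compound 2 (1.03 log units; beyond the scatter), a step well beyond what repeated measurements usually scatter by.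

Compound 3 `CC(O)(CS(=O)(=O)c1cccc(C(F)(F)F)c1)C(=O)Nc1ccc(S(F)(F)(F)(F)F)cc1` carries a different core; how the two cores differ is not broken down here. In this assay compound 3 gives 21000 nM, a number that sits within the usual scatter of the value for compound 1.

Compound 4 `CC(O)(CS(=O)(=O)c1cc(C(F)(F)F)cc(C(F)(F)F)c1)C(=O)Nc1ccc(S(F)(F)(F)(F)F)cc1` has not yet been measured. It stands to compound 3 exactly as compound 2 stands to compound 1, with the same change at the same kind of place: trifluoromethyl in place of hydrogen on an aromatic carbon. Since the starting points of the two pairs lie so close together, the expected step is an 8.4-fold lower number from compound 3 to compound 4 (0.92 log units; beyond the scatter), and that expectation rests on the measured step of an 11-fold lower number from compound 1 to compound 2 (1.03 log units; beyond the scatter). Compound 4 is therefore estimated at about 2500 nM in this assay, most likely between 900 nM and 7000 nM.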

Compound 4, half-maximal inhibitory concentration: 13300 nM
Compound 4: the middle estimate sits 5.3-fold (0.73 log units) below what was measured; measured number outside the range, above it.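

On the core of compound 3, the added trifluoromethyl gives a 1.6-fold lower number from compound 3 to compound 4 (0.20 log units; within the scatter) in this assay, a step that cannot be told apart from the differences seen between repeated measurements. The same change therefore does not carry over at the same size from one core to the other: the same change on two cores in this assay, an 11-fold lower number (1.03 log units; beyond the scatter) from compound 1 to compound 2 and a 1.6-fold lower number (0.20 log units; within the scatter) from compound 3 to compound 4, 6.8-fold (0.83 log units) apart, beyond the scatter of two such steps. This shows that, across these four compounds, the size of the step depends on the core it is made on, but it does not show what about the cores causes the gap, and a single comparison on two cores gives no rule for a third.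

The compounds shown vary only trifluoromethyl at this place on the aromatic ring, so it remains open whether an amine, a nitrile or a carboxylic acid there would also give steps that differ between the two cores. On these data alone, it is also open which of the two measured steps, if either, a core with a longer chain leading to the ring would follow.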